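Shortening the alkoxy chain and tolerance by skin cells

The compounds below may be only part of what the source reports. "The series", "measured", "known", "first", "only" and "open" are said of these compounds alone.

Measured so far:
compound 1 `CCCCCOc1nc(N)nc2c1ncn2/C=C1/CC1(CO)CO` gives 259000 nM
compound 2 `Nc1nc(N2CCCC2)c2ncn(/C=C3/CC3(CO)CO)c2n1` gives > 300000 nM
compound 3 `COCCOc1nc(N)nc2c1ncn2/C=C1/CC1(CO)CO` gives > 300000 nM

All three share one core and differ only in the group on an aromatic carbon. Among the measured compounds shown here, in an ADME assay on HFF cells (Homo sapiens) for cytotoxicity, with a stated time of 8 days (a higher number here means that more compound is tolerated, a lower number that less compound is tolerated), compound 1 is the only one with a plain number, 259000 nM. Compound 2 reaches only a limit of the assay, > 300000 nM. Compound 3 likewise stops at a limit, > 300000 nM. Both neighbouring steps are therefore read as floors: an at least 1.1-fold higher number from compound 1 to compound 2 (0.06 log units; that floor lies within the scatter), and an at least 1.1-fold higher number from compound 1 to compound 3 (0.06 log units; that floor lies within the scatter), each of which lies within the scatter, so there is no sign yet that any change at this position alters tolerance.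

Compound 4 `C=CCOc1nc(N)nc2c1ncn2/C=C1/CC1(CO)CO` is not yet measured. It differs from compound 1 as follows: vinyl in place of butyl on a saturated chain carbon bound to an oxygen on an aromatic ring. The two changes already seen at this position, one to pyrrolidin-1-yl and one to 2-methoxyethoxy, each left the number within the scatter of compound 1, so no step beyond the scatter is expected here either, and a result at the limit, as for compound 2 and compound 3 (the limit of > 300000 nM in this assay, at which 2 of the 3 values shown sit), is quite possible. Compound 4 is therefore estimated at 300000 nM, between 150000 nM and 600000 nM, which is an expected step of a 1.2-fold higher number from compound 1 to compound 4 (0.06 log units; within the scatter).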

Compound 4, half-maximal cytotoxic concentration: > 300000 nM
Compound 4: a limit, no number; the forecaster's own chance of this, stated with the estimate: 55%; the middle value lies on the limit itself.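

In this assay, from the compounds shown here alone, vinyl in place of butyl on a saturated chain carbon bound to an oxygen on an aromatic ring gives an at least 1.1-fold higher number from compound 1 to compound 4 (0.06 log units; that floor lies within the scatter); this is a floor set by a limit of the assay, so the true size of the step stays unknown. Allyloxy is a third kind of group to end at a limit, after pyrrolidin-1-yl and 2-methoxyethoxy, so that outcome is now shared by three differently built groups at this position: the limit of > 300000 nM in this assay, at which 3 of the 4 values shown sit. The steps among compound 2, compound 3 and compound 4 all run between two limits and cannot be read.

Going by these compounds, whether a longer chain such as octyloxy, or a carboxylic acid at this position, would give a plain number stays open. Also open, on these data alone, is whether compound 2, compound 3 and compound 4 differ at all in how well they are tolerated.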